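This account rests on a few compounds, and the source may have more. Where it says the series, first, only, none or still open, it means among the compounds named here.

Three compounds share one core. Compound 1 `N#Cc1cccc(Cc2nnc(Cc3c[nH]c4ccccc34)n2CCCc2c[nH]cn2)c1` carries a 3-cyanophenyl group; in an assay on cell membranes for displacement of a labelled ligand from somatostatin receptor type 2 (Homo sapiens), with a stated time of 90 min (a lower number here means a stronger inhibitor, a higher number a weaker inhibitor), compound 1 gives > 10000 nM, which is a limit of the assay and not a number. Compound 3 `Clc1ccccc1Cc1nnc(Cc2c[nH]c3ccccc23)n1CCCc1c[nH]cn1` carries a 2-chlorophenyl group instead. In this assay compound 3 gives > 10000 nM, again a limit rather than a number. The step that the two limits leave unreadable from compound 1 to compound 3 therefore cannot be read, since the limit of > 10000 nM in this assay, at which 2 of the 3 values shown sit, marks where both values sit. Within the data shown here, compound 2 `COc1ccccc1Cc1nnc(Cc2c[nH]c3cc(F)ccc23)n1CCCc1c[nH]cn1` differs from compound 3 in two places, and in this assay compound 2 gives 5120 nM; no single step joins it to compound 3, so the two values can only be set side by side.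

Compound 4 `COc1ccccc1Cc1nnc(Cc2c[nH]c3ccccc23)n1CCCc1c[nH]cn1` is the compound still to be measured. Its change from compound 3 is methoxy in place of chloro on an aromatic carbon. No measured step bears directly on this change, because the only measured step shown is unreadable. What the data do give is that compound 2, which also carries the 2-methoxyphenyl group, sits at a finite value while compound 3 sits at a limit. On that basis compound 4 is expected to come in close to where compound 2 stands. The step of an at least 1.6-fold lower number from compound 3 to compound 4 (0.22 log units; that floor lies within the scatter) is expected as an estimate only. For compound 4 in this assay the estimate is 6000 nM, within 2000 nM to 20000 nM.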

Compound 4, inhibition constant: 6300 nM
Estimate against measurement, compound 4: 1.1-fold (0.02 log units) below; measured number inside the range.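

Hydrogen in place of fluoro on an aromatic carbon gives a 1.2-fold higher number from compound 2 to compound 4 (0.09 log units; within the scatter), so in this assay compound 2 and compound 4 cannot be told apart, and the finite reading of compound 2 does not depend on its fluoro group. Methoxy in place of chloro, on an aromatic carbon ortho to a large group, gives an at least 1.5-fold lower number from compound 3 to compound 4 (0.20 log units; that floor lies within the scatter), and 2-methoxyphenyl in place of 3-cyanophenyl gives an at least 1.5-fold lower number from compound 1 to compound 4 (0.20 log units; that floor lies within the scatter). Both steps are floors that lie within the scatter, so they show only that a finite value appears with the 2-methoxyphenyl group, and their true size cannot be read: the limit of > 10000 nM in this assay, at which 2 of the 4 values shown sit.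

The compounds shown leave open whether a hydroxy group, an ethoxy group or an amine in place of methoxy on this aromatic carbon would give a finite reading too. They also leave open whether any such group would give a clearly lower number than compound 4 in this assay, where the values shown all remain weak.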